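Turning One Ring Stereocentre on a Shared Core

The source may report more compounds than this note shows. Statements on the series, on what has been measured and on what is new or still open speak of the compounds shown alone.

Measured compounds:
compound 1 `Cc1ccc2[nH]c(C(=O)N[C@H]3CCN(S(=O)(=O)c4ccccc4)C[C@@H]3C(=O)NCCN(C)C)cc2c1` gives 98%
compound 2 `Cc1ccc2[nH]c(C(=O)N[C@H]3CN(S(=O)(=O)c4ccccc4)C[C@H]3C(=O)NCCN(C)C)cc2c1` gives 72%
compound 3 `Cc1ccc2[nH]c(C(=O)N[C@H]3CN(S(=O)(=O)c4ccccc4)CC[C@@H]3C(=O)NCCN(C)C)cc2c1` gives 81%

In a functional assay on HEK293 cells for agonist activity at growth hormone secretagogue receptor type 1 (Homo sapiens), read by HTRF and inositol phosphate accumulation, with a stated time of 90 min, in the presence of a further agent that is not named here (a lower number here means a smaller maximal response, a higher number a larger maximal response), compound 3 stands second highest of the three numbers shown. Its nearest neighbour is compound 2, whose number is lower by an amount that stays within the usual scatter, so the two cannot be ordered. The furthest is compound 1, whose number is higher by an amount beyond the scatter. Compound 4 `Cc1ccc2[nH]c(C(=O)N[C@H]3CN(S(=O)(=O)c4ccccc4)CC[C@H]3C(=O)NCCN(C)C)cc2c1` is not yet measured. Its difference from compound 3 is counted as the two compounds have the same atoms and bonds and differ only in configuration as drawn: 1 of 2 stereo elements differ; a stereocentre at a saturated ring carbon is drawn S in compound 3 and R in compound 4. For the measured compounds named here, no measured pair in this set differs only in configuration, so there is no directly comparable step to lean on. The account therefore expects a step from compound 3 to compound 4 of a number 7 percentage points lower from compound 3 to compound 4 (within the scatter) in this assay, most likely a modest fall, with a fair chance that it stays within the scatter. Compound 4 is estimated at 74% in this assay, with a range from 45% to 100%.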

Compound 4, largest response reached (Emax), in percent of the reference or control that the assay uses in the growth hormone secretagogue receptor type 1 assay: 68%
Beside the measured number, compound 4's estimate is 6 percentage points above it, and the stated range covers the measured number.
By their numbers in the growth hormone secretagogue receptor type 1 assay, from the lowest: compounds 4, 2 and 3 (each within the scatter of the next, the first and the last beyond it); then compound 1.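

For the compounds shown here, in the growth hormone secretagogue receptor type 1 assay, this pair gives the first comparison of configuration alone, with a number 13 percentage points lower from compound 3 to compound 4 (beyond the scatter), so turning the stereocentre at a saturated ring carbon from S to R shifts the maximal response modestly. That step can be laid on this single stereocentre, and the ground for doing so is: the fact that compounds 3 and 4 differ only in the configuration as drawn In a physicochemical assay for lipophilicity, measured as octanol-water partition, at pH 7.4 (a lower number here means a more polar compound, a higher number a more lipophilic compound), compound 3 gives 1.9 and compound 4 gives 1.9, with no change at the digits printed from compound 3 to compound 4 (within the scatter), so the fall in maximal response comes without a measurable shift in distribution coefficient.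

The compounds shown leave open what happens when the second stereocentre is turned, alone or together with the first. They also leave open whether a carboxylic acid or a longer chain on the shared core would keep the same gap between the two configurations.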